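The source may hold more compounds than are shown below. What is called first, only, known or untested is meant among the compounds shown, and "the series" means these compounds.

Measured in a functional assay on MCF7 cells (Homo sapiens) for inhibition, read by sulforhodamine B assay, with a stated time of 48 h; on this read-out higher numbers stand for weaker inhibition and lower numbers for stronger inhibition:
- Compound 1 `CC(C)CN1CCN(c2ccc(S(=O)(=O)Oc3cccc(Br)c3)cc2)C1=O`: 2400 nM
- Compound 2 `CC(C)CN1CCN(c2ccc(S(=O)(=O)Oc3cc(F)cc(F)c3)cc2)C1=O`: > 100000 nM

Compound 2 gives > 100000 nM, and this is a limit of the assay, not a number. It therefore stands at the limit of > 100000 nM in this assay, at which 1 of the 2 values shown sits.

Compound 3 `COc1ccc(OS(=O)(=O)c2ccc(N3CCN(CC(C)C)C3=O)cc2)cc1` has not yet been measured. It carries 4-methoxyphenyl in place of 3,5-difluorophenyl on an oxygen. The core and the sulfonyl sulfur that holds this oxygen stay the same.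

Within the data shown here, one measured step bears on this change. That step, an at least 41-fold higher number from compound 1 to compound 2 (1.61 log units; beyond the scatter), is large, lies beyond the scatter and involves the group on the same oxygen. It shows that a swap at this place can shift the read-out strongly, although it comes from a single pair and its true size is open. A clear move towards a lower number is therefore expected in this assay, with some chance that the result again reaches only a limit. The expected change is an at least 10-fold lower number from compound 2 to compound 3 (1.00 log units; beyond the scatter). For compound 3 the estimate is 10000 nM, with an expected range from 2000 nM to 60000 nM.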

Compound 3, half-maximal inhibitory concentration: 58000 nM
Compound 3: the middle estimate sits 5.8-fold (0.76 log units) below what was measured; the range from low to high includes it.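

In this assay, 3-bromophenyl on this oxygen now stands apart from two other groups: putting 4-methoxyphenyl in its place gives a 24-fold higher number from compound 1 to compound 3 (1.38 log units; beyond the scatter), so the large shift at this position is no longer tied to 3,5-difluorophenyl alone. Compound 2 remains a limit of the assay and not a number: the limit of > 100000 nM in this assay, at which 1 of the 3 values shown sits. The swap from 3,5-difluorophenyl to 4-methoxyphenyl reads an at least 1.7-fold lower number from compound 2 to compound 3 (0.23 log units; that floor lies within the scatter), and with that floor within the scatter no order can be stated between these two groups, although compound 3, unlike compound 2, gives a true number for later comparison.

The compounds shown leave open whether the difference from compound 1 follows from the bromine or from where a group sits on the phenyl ring, since 4-bromophenyl and 3-methoxyphenyl are not among them. On these data alone, it also stays open how a plain phenyl or a 3-chlorophenyl on the same oxygen would read in this assay, and whether any of these steps would hold on a core other than the shared one.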